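The source may hold more compounds than are shown below. What is called first, only, known or untested is meant among the compounds shown, and "the series" means these compounds.

Measured compounds and their values:
compound 1, `CC(C)(C)OC(=O)N1CCN(C(=S)SCc2cn(-c3ccccc3F)nn2)CC1`: 89600 nM
compound 2, `CC(C)(C)OC(=O)N1CCN(C(=S)SCc2cn(Cc3ccc(Cl)cc3)nn2)CC1`: 2960 nM
compound 3, `O=C(OCc1ccccc1)N1CCN(C(=S)SCc2cn(Cc3ccc(Cl)c(Cl)c3)nn2)CC1`: 10600 nM

All three numbers come from a functional assay on MCF7 cells (Homo sapiens) for inhibition, read by MTT assay, with a stated time of 72 h; a higher number here means a weaker inhibitor, a lower number a stronger inhibitor. Among them compound 3 has the second highest number: its nearest neighbour is compound 2, whose number is lower, and its furthest is compound 1, whose number is higher, both gaps lying beyond the scatter.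

Compound 4, `CC(C)(C)OC(=O)N1CCN(C(=S)SCc2cn(Cc3ccc(Cl)c(Cl)c3)nn2)CC1`, is the next compound to be tested. Going by the values given here, its single change from compound 3 is tert-butyl in place of benzyl on an oxygen next to a carbonyl group, that is, the benzyloxycarbonyl on the shared core becomes a tert-butoxycarbonyl.

Among the compounds with values here, the only measured step, a 30-fold lower number from compound 1 to compound 2 (1.48 log units; beyond the scatter), concerns the group on the aromatic nitrogen of the triazole and therefore says nothing directly about the change from benzyl to tert-butyl on the oxygen. What can be said is that compound 2 already carries the tert-butoxycarbonyl and gives 2960 nM, a lower number than compound 3, though compound 2 also differs from compound 4 at the benzyl ring. On this thin evidence the step of a 2.1-fold lower number from compound 3 to compound 4 (0.33 log units; beyond the scatter) is expected to be modest and downward, and compound 4 is estimated at 5000 nM, with a range from 1500 nM to 16000 nM.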

Compound 4, half-maximal inhibitory concentration: 19100 nM
Compound 4: the middle estimate sits 3.8-fold (0.58 log units) below what was measured; the measured number lies above the stated range.
By their numbers in this assay, from the lowest: compound 2; then compounds 3 and 4 (each within the scatter of the next); then compound 1.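

In this assay, tert-butyl in place of benzyl on an oxygen next to a carbonyl group gives a 1.8-fold higher number from compound 3 to compound 4 (0.26 log units; within the scatter) and so makes no readable difference: with the 3,4-dichlorobenzyl group held fixed, a group with an aromatic ring and a group with no ring perform alike at this position. The other two comparisons involve the group on the aromatic nitrogen: chloro in place of hydrogen on an aromatic carbon gives a 6.5-fold higher number from compound 2 to compound 4 (0.81 log units; beyond the scatter) and 3,4-dichlorobenzyl in place of 2-fluorophenyl gives a 4.7-fold lower number from compound 1 to compound 4 (0.67 log units; beyond the scatter), both beyond the scatter, so among these compounds the nitrogen substituent changes the number while the swap on the oxygen does not. No measurement here accounts for any of these steps.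

On these data alone, it remains open whether benzyl and tert-butyl would also match each other on a compound carrying only the 4-chlorobenzyl group, since the two-compound comparison at the oxygen rests on a single pair. As far as these compounds go, it is also open how the number would respond to a quite different group at this oxygen, such as a longer chain ending in an amine or a carboxylic acid.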